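Acetyl to methoxycarbonyl: working notes on compound 3

The compounds below may be only part of what the source reports. "The series", "measured", "known", "first", "only" and "open" are said of these compounds alone.

Measured in an ADME assay on a cell-free system (plasma, Rattus norvegicus, strain Sprague-Dawley) for protein binding
compound 1 `O=C(Nc1cccnc1)Nc1cc(F)cc(Oc2cccnc2)c1` gives 92.9%
compound 2 `CC(=O)N1CCC[C@@H](Oc2cc(F)cc(NC(=O)Nc3cccnc3)c2)C1` gives 82.5%

Compound 2 holds the higher unbound fraction of the two measured compounds. Among the compounds with values here, the only measured step shows a 2.5-fold higher unbound fraction from compound 1 to compound 2 (0.39 log units; beyond the scatter) and comes with 1-acetylpiperidin-3-yl in place of pyridin-3-yl on an oxygen on an aromatic ring.

Compound 3 `COC(=O)N1CCC[C@@H](Oc2cc(F)cc(NC(=O)Nc3cccnc3)c2)C1` keeps the rest of compound 2 and has methoxy in place of methyl on a carbonyl carbon, that is acetyl to methoxycarbonyl methoxy in place of methyl on a carbonyl carbon in this one place. Within the data shown here, no measured step covers this change. The step from compound 1 bears on it only loosely, as the one size available, and it exchanged a whole group on the oxygen, whereas here only the end of that group differs. A smaller step is therefore expected in this assay with a slight lean towards more bound compound, though the data do not settle the direction. The expected step is a 1.3-fold lower unbound fraction from compound 2 to compound 3 (0.10 log units; within the scatter) and no shift beyond the scatter is expected. For compound 3 the estimated value is 86% with an expected range from 78% to 92% in this estimate.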

Compound 3, plasma protein binding: 90.4%
The estimate for compound 3 lay 1.5-fold (0.16 log units) (unbound fraction) above the measured number; low and high end bracket the measured number.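

In this assay, within the data shown here, the only reading at this place is a 1.8-fold lower unbound fraction from compound 2 to compound 3 (0.26 log units; within the scatter), so methoxy in place of methyl on a carbonyl carbon gives no shift that can be told apart from repeat measurements. The step from compound 1 to compound 2 exchanged a whole group on the oxygen and could say nothing about the end of that group; this pair shows that the end of the group can take on an oxygen and a hydrogen-bond acceptor with the read-out staying within the scatter. Nothing at hand explains the values of this pair, and with a step of this size there is no direction to explain.

The compounds shown leave open whether a longer chain on the carbonyl carbon, such as ethoxy or butoxy, or an amine in place of methoxy, would carry the read-out in this assay beyond the scatter. With one pair at this place, they also leave open whether acetyl to methoxycarbonyl would read the same way on any other core.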